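This account rests on a few compounds, and the source may have more. Where it says the series, first, only, none or still open, it means among the compounds named here.

Measured in a functional assay on the whole organism for inhibition, with Rattus norvegicus as the target, with a stated time of 1 h, at a dose of 25 mg/kg by the oral route; a lower number here means less inhibition, a higher number more inhibition at the dose given (going by the name of the read-out):
Compound 1 `CC1(C)OC(/C=C/c2cc(Cl)cc(Cl)c2)=CC1=O` gives 63%.
Compound 2 `CC1(C)OC(/C=C/c2ccc(S(C)(=O)=O)cc2)=CC1=O` gives 56%.
Compound 3 `CC1(C)OC(c2ccc(Br)cc2)=CC1=O` gives 36%.

Compound 2 stands second highest of the three. Its nearest neighbour is compound 1, whose number lies within the scatter of it; compound 3 is furthest, with a number beyond the scatter below it.

Compound 4 `CC1(C)OC(/C=C/c2ccc(C(F)(F)F)cc2)=CC1=O` has not been measured. It differs from compound 2 in one place: trifluoromethyl in place of methylsulfonyl on an aromatic carbon.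

Within the data shown here, no pair of measured compounds differs in one place, so no measured step is available for this kind of change. Among the measured compounds shown here, compounds 1 and 2, which carry different groups on the ring yet give numbers within the scatter of each other, are the only guide. The step from compound 2 to compound 4 in this assay is therefore expected to be a number 1 percentage points higher from compound 2 to compound 4 (within the scatter), no change beyond the scatter in either direction. For compound 4 the expected value is 57%, within 40% to 74%.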

Compound 4, a percentage reported as inhibition, in the whole organism at one dose (the size of the read-out at that dose, not a potency): 30%
For compound 4 the middle estimate is 27 percentage points above the measured one; measured number below the stated range.
By their numbers in this assay, from the lowest: compounds 4 and 3 (each within the scatter of the next); then compounds 2 and 1 (each within the scatter of the next).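

In this assay, among these compounds, trifluoromethyl in place of methylsulfonyl on this aromatic carbon, para to a large group, gives a number 26 percentage points lower from compound 2 to compound 4 (beyond the scatter) and is the first one-place change available. Among the compounds shown here, the group on this carbon therefore bears on the inhibition read-out, which the earlier compounds, none of them a one-place pair, could not show. Nothing at hand accounts for the step. Still open, going by these compounds, is how other groups on this carbon, such as a nitrile, an amine or a carboxylic acid, would read. Also open, on these data alone, is whether the same change gives a step of similar size on another core.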